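Cyclohexyl to phenyl at the piperidine carbon bearing the large group

The source may hold more compounds than are shown below. What is called first, only, known or untested is meant among the compounds shown, and "the series" means these compounds.

Measured so far:
compound 1 `Cc1ccc(S(=O)(=O)N2CCC(Cl)CC2)cc1` — > 100000 nM
compound 2 `Cc1ccc(S(=O)(=O)N2CC[C@@H](Cl)C[C@@H]2C2CCCCC2)cc1` — 53000 nM

In a functional assay on SW1573 cells (Homo sapiens) for antiproliferative activity, read by sulforhodamine B assay, with a stated time of 48 h (a lower number here means a stronger inhibitor of growth, a higher number a weaker inhibitor of growth), compound 1 gives only a limit, > 100000 nM. In this assay, for the measured compounds named here, compound 2 gives 53000 nM, the only actual number in the set. The step of an at least 1.8-fold lower number from compound 1 to compound 2 (0.27 log units; that floor lies within the scatter) rests on that limit, (the limit of > 100000 nM in this assay, at which 1 of the 2 values shown sits), and so sets only a floor. Compound 3 `Cc1ccc(S(=O)(=O)N2CC[C@@H](Cl)C[C@@H]2c2ccccc2)cc1` differs from compound 2 by phenyl in place of cyclohexyl on a saturated ring carbon. Going by the values given here, no measured step covers this exchange, so compound 3 is expected to stay close to compound 2, with a 1.0-fold higher number from compound 2 to compound 3 (0.02 log units; within the scatter) inside the scatter. Compound 3 is expected at 55000 nM, between 20000 nM and 140000 nM.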

Compound 3, concentration for 50% growth inhibition: > 100000 nM
Compound 3 ended at the assay's limit; the forecaster's own chance of this, stated with the estimate: 30%; middle value at least 1.8-fold (0.25 log units) away from the limit.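

In this assay, phenyl on this saturated ring carbon next to the ring nitrogen gives no measurable number, with an at least 1.8-fold higher number from compound 2 to compound 3 (0.27 log units; that floor lies within the scatter). For the compounds shown here, that floor does not establish a real loss, but the cyclohexyl of compound 2 remains the only group here with an actual number. The step from compound 1 to compound 3 cannot be read because both compounds stand at a limit: the limit of > 100000 nM in this assay, at which 2 of the 3 values shown sit.

Still open, from the compounds shown here alone, is whether cyclohexyl and phenyl truly differ at this position. Also open, going by these compounds, is whether an amine on the phenyl ring or a longer alkyl chain in its place would give a lower number.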